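Trading trifluoromethyl for chloro on the urea aryl ring

A few compounds are considered here, and "the series" means these few. Any claim that something is new, unique, unknown or untested is made for them only; others in the source may bear on it.

Measured so far:
- compound 1, `COc1cc2cc(Oc3ccc(NC(=O)Nc4cccc(C(F)(F)F)c4)cc3)c(C)nc2cc1OC`: 10100 nM
- compound 2, `COc1cc2cc(Oc3ccc(NC(=O)Nc4ccc(Cl)c(C(F)(F)F)c4)cc3)c(C)nc2cc1OC`: 4710 nM

Of the compounds shown here, two have been tested so far in a functional assay on MDA-MB-435 cells (Homo sapiens) for inhibition, read by sulforhodamine B assay, with a stated time of 48 h; on this read-out higher numbers stand for weaker inhibition of growth and lower numbers for stronger inhibition of growth. Compound 1 gives 10100 nM. Among the compounds with values here, compound 2 gives 4710 nM, which is the lowest of the two numbers; the only step measured is a 2.1-fold lower number from compound 1 to compound 2 (0.33 log units; beyond the scatter).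

Compound 3, `COc1cc2cc(Oc3ccc(NC(=O)Nc4ccc(Cl)c(Cl)c4)cc3)c(C)nc2cc1OC`, is not yet measured. It differs from compound 2 by chloro in place of trifluoromethyl on an aromatic carbon. Within the data shown here, no measured step covers this particular swap; the one step that exists, from compound 1 to compound 2, concerns adding a chloro where hydrogen stood, and was modest. The change from compound 2 to compound 3 keeps that chloro and replaces the neighbouring trifluoromethyl with a second chloro, so the expectation is a step of at most modest size in this assay, with no clear direction, most likely within the usual scatter. On that basis compound 3 is expected to give about 6000 nM, with a range of 2500 nM to 15000 nM, which corresponds to an expected step of a 1.3-fold higher number from compound 2 to compound 3 (0.11 log units; within the scatter).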

Compound 3, concentration for total growth inhibition: 16800 nM
Compound 3: the middle estimate sits 2.8-fold (0.45 log units) below what was measured; the measured number lies above the stated range.
By their numbers in this assay, from the lowest: compound 2; then compounds 1 and 3 (each within the scatter of the next).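

In this assay, chloro does not stand in for trifluoromethyl at this position on the urea aryl ring: the swap gives a 3.6-fold higher number from compound 2 to compound 3 (0.55 log units; beyond the scatter), something the earlier step, which only added a chloro where hydrogen stood, could not reveal. The second new comparison gives a 1.7-fold higher number from compound 1 to compound 3 (0.22 log units; within the scatter), so the 3,4-dichlorophenyl and 3-(trifluoromethyl)phenyl compounds cannot be told apart, and the gain from a 2.1-fold lower number from compound 1 to compound 2 (0.33 log units; beyond the scatter) appears among these three compounds only in the one that carries both chloro and trifluoromethyl. Nothing available here bears on why the swap behaves this way.

On these data alone, it remains open whether a bromo, a methyl or a nitrile in place of the trifluoromethyl would give a number close to that of compound 2 or close to that of compound 3. It is also open whether the trifluoromethyl-to-chloro swap would give a step of similar size with hydrogen, rather than chloro, as its ring neighbour, since the only pair shown for this swap keeps that chloro.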